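Fluorophenyl change from compound 3 to compound 4

A few compounds are considered here, and "the series" means these few. Any claim that something is new, unique, unknown or untested is made for them only; others in the source may bear on it.

Values in an ADME assay on HUVEC cells (Homo sapiens) for inhibition, read by CCK-8 assay, with a stated time of 24 h, in the presence of a further agent that is not named here; on this read-out higher numbers stand for weaker inhibition and lower numbers for stronger inhibition:
- compound 1 `Cc1ccccc1-n1cc(-c2ccc(/C=C3\C(=O)Nc4ccccc43)cc2)nn1`: 14700 nM
- compound 2 `Cc1cccc(-n2cc(-c3ccc(/C=C4\C(=O)Nc5ccccc54)cc3)nn2)c1`: 13700 nM
- compound 3 `O=C1Nc2ccccc2/C1=C/c1ccc(-c2cn(-c3cccc(F)c3)nn2)cc1`: > 20000 nM (a limit, not a number)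

Compound 3 has no number of its own and sits at the limit of > 20000 nM in this assay, at which 1 of the 3 values shown sits. Compound 4 `O=C1Nc2ccccc2/C1=C/c1ccc(-c2cn(-c3ccc(F)cc3)nn2)cc1` carries 4-fluorophenyl in place of 3-fluorophenyl on an aromatic nitrogen. The one measured shift of a group around a phenyl is a 1.1-fold lower number from compound 1 to compound 2 (0.03 log units; within the scatter), which stays within the scatter. Two further steps, an at least 1.3-fold higher number from compound 1 to compound 3 (0.13 log units; that floor lies within the scatter) and an at least 1.4-fold higher number from compound 2 to compound 3 (0.16 log units; that floor lies within the scatter), give only floors. No change beyond the scatter is therefore expected in this assay, and another limit is possible. The expected step is an at least 1.1-fold lower number from compound 3 to compound 4 (0.04 log units; that floor lies within the scatter). Compound 4 is expected at 18000 nM, with an estimated range of 9000 nM to 32000 nM.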

Compound 4, half-maximal inhibitory concentration: 14700 nM
Beside the measured number, compound 4's estimate is 1.2-fold (0.09 log units) above it; measured number inside the range.
By their numbers in this assay, from the lowest: compounds 2, 1 and 4 (each within the scatter of the next). At a limit, above all of these: compound 3.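

In this assay, 4-fluorophenyl in place of 3-fluorophenyl gives a measured number where the earlier fluoro compound gave none, yet the step, an at least 1.3-fold lower number from compound 3 to compound 4 (0.13 log units; that floor lies within the scatter), has a floor within the scatter. Compound 3 remains a limit, not a number: the limit of > 20000 nM in this assay, at which 1 of the 4 values shown sits. The other two steps, a 1.1-fold higher number from compound 2 to compound 4 (0.03 log units; within the scatter) and no change at the digits printed from compound 1 to compound 4 (within the scatter), leave 4-fluorophenyl, 3-methylphenyl and 2-methylphenyl not told apart on this nitrogen.

From the compounds shown here alone, the true gap between the two fluorophenyl compounds stays open. Also open, going by these compounds, is whether an amine or carboxylic acid on this phenyl, or a longer chain in its place, would move the number beyond the scatter.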